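Benzoyl in place of pyridinecarbonyl on the shared core

The compounds below may be only part of what the source reports. "The series", "measured", "known", "first", "only" and "open" are said of these compounds alone.

Of the compounds shown here, three have been measured in an assay on CHO cells for displacement of a labelled ligand from adenosine receptor A1 (Homo sapiens), read by scintillation counting, with a stated time of 120 min, tested at 1 uM; on this read-out higher numbers stand for more inhibition at the one concentration tested (going by the name of the read-out) and lower numbers for less inhibition. Compound 1 `COc1ccc(-c2nc(NC(=O)c3ccncc3)c3nn(-c4ccccc4)cc3n2)cc1` gives 3% in this assay. Compound 2 `COc1ccc(-n2cc3nc(-c4cccs4)nc(N)c3n2)cc1` gives 28%, and compound 3 `O=c1[nH]c(-c2cccs2)nc2cn(-c3ccccc3)nc12` gives 6%. Compound 1 thus carries the lowest of the three numbers; its gap to compound 3 lies within the usual scatter of repeated measurements, whereas its gap to compound 2 lies beyond it. Within the data shown here, no two measured compounds differ in only one place, so no single structural step has a measured size here.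

Compound 4 `COc1ccc(-c2nc(NC(=O)c3ccccc3)c3nn(-c4ccccc4)cc3n2)cc1` has not yet been measured. It differs from compound 1 in one place: phenyl in place of pyridin-4-yl on a carbonyl carbon. Among the measured compounds shown here, nothing among the measured compounds shows how this exchange shifts the read-out in this assay. Since compound 1 gives 3%, little room lies below it, and the step of a number 5 percentage points higher from compound 1 to compound 4 (within the scatter) is expected to be small, not beyond the scatter in either direction. Compound 4 is therefore estimated at 8%, with a range from -5% to 25%.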

Compound 4, a percentage reported as inhibition, at one concentration (the size of the read-out at that concentration, not a potency): 2%
Estimate against measurement, compound 4: 6 percentage points above, and the stated range covers the measured number.
By their numbers in this assay, from the lowest: compounds 4, 1 and 3 (each within the scatter of the next); then compound 2.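

In this assay, among these compounds, the exchange of pyridin-4-yl for phenyl on a carbonyl carbon gives the first measured step on this core (a number 1 percentage points lower from compound 1 to compound 4 (within the scatter)). At this position, then, replacing the pyridine ring with a ring of carbon only makes no readable difference, although compound 1 at 3% and compound 4 at 2% both sit so close to zero that a further loss could hardly show. No evidence is available that accounts for this result.

As far as these compounds go, whether a saturated amine such as piperidin-4-yl or a longer alkyl chain on this carbonyl carbon would lift the number remains open. The compounds shown also do not tell whether the same exchange would stay as small on a compound with a higher starting value.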